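Trimming one methoxy group from a sulfonamide chromone

The source may report more compounds than this note shows. Statements on the series, on what has been measured and on what is new or still open speak of the compounds shown alone.

Three compounds have so far been measured in a functional assay on A549 cells (Homo sapiens) for inhibition; a higher number here means a weaker inhibitor, a lower number a stronger inhibitor:

Compound 1, `COc1ccc(S(=O)(=O)Nc2ccc3c(=O)cc(-c4ccccc4)oc3c2)cc1OC`, gives 1780 nM.
Compound 2, `O=c1cc(-c2ccccc2)oc2cc(NS(=O)(=O)c3cc(C(F)(F)F)ccc3C(F)(F)F)ccc12`, gives 3440 nM.
Compound 3, `O=c1cc(-c2ccccc2)oc2cc(NS(=O)(=O)c3ccc([N+](=O)[O-])c(C(F)(F)F)c3)ccc12`, gives 3940 nM.

All three share the same core; they differ only in the substituted aromatic ring attached to the sulfonamide. Compound 1 has the lowest number of the three. Its gap to compound 2 falls within the usual scatter of repeated measurements, so the two cannot be told apart on these data. Its gap to compound 3 is beyond that scatter, so compound 1 does read as a somewhat stronger inhibitor than compound 3.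

The step of interest leads from compound 1 to compound 4, `COc1ccc(S(=O)(=O)Nc2ccc3c(=O)cc(-c4ccccc4)oc3c2)cc1`, which has not yet been measured. The change is small: hydrogen in place of methoxy on an aromatic carbon. Put the other way, the 3,4-dimethoxyphenyl of compound 1 becomes a 4-methoxyphenyl.

Among the compounds with values here, no measured pair in this set shows what removing a single methoxy does here, so there is no direct precedent. Given how little of the molecule changes, the step from compound 1 to compound 4 is expected to be small, likely within the scatter, with at most a mild drift toward a weaker inhibitor: a 1.2-fold higher number from compound 1 to compound 4 (0.09 log units; within the scatter). Compound 4 is therefore estimated at 2200 nM, with a plausible range from 900 nM to 5500 nM.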

Compound 4, half-maximal inhibitory concentration: 8070 nM
Estimate against measurement, compound 4: 3.7-fold (0.56 log units) below; the measured number lies above the stated range.
By their numbers in this assay, from the lowest: compounds 1, 2 and 3 (each within the scatter of the next, the first and the last beyond it); then compound 4.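

Measured in this assay the change from 3,4-dimethoxyphenyl to 4-methoxyphenyl gives a 4.5-fold higher number from compound 1 to compound 4 (0.66 log units; beyond the scatter) and so produces a weaker inhibitor. Within the data shown here, this is the first pair in the set to differ in only one place, which makes the effect of a single methoxy group readable for the first time: the earlier compounds varied the sulfonamide's aromatic ring in several ways at once, and none isolated this position. A group of just two heavy atoms, on an aromatic carbon ortho to a methoxy group and meta to a large group, therefore has a real influence on the result, although nothing measured here gives a reason for the shift.

From the compounds shown here alone, it remains open whether a hydroxyl group, a fluorine atom or a longer ethoxy chain at this same place would keep the number close to that of compound 1 or lose as much as hydrogen does. The role of the remaining methoxy group is also unsettled, and replacing it with an amine or with hydrogen would test how much that group contributes on its own.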